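From Nitrile to Tetrazole at the Chain End

The source may report more compounds than this note shows. Statements on the series, on what has been measured and on what is new or still open speak of the compounds shown alone.

In a functional assay for inhibition, with Homo sapiens as the target (on this read-out lower numbers stand for stronger inhibition and higher numbers for weaker inhibition), compound 3 `N#CCCCCCCCCn1nc(-c2ccccc2)c(-c2ccccc2)c1-c1ccccc1` gives no number, only a limit (> 72000 nM). Compound 2 `CNC(=O)CCCCCCCCn1nc(-c2ccccc2)c(-c2ccccc2)c1-c1ccccc1` also gives only a limit (> 68000 nM). Compound 1 `O=C(O)CCCCCCCCCn1nc(-c2ccccc2)c(-c2ccccc2)c1-c1ccccc1` is the one of these three with a measured number (5500 nM). Compound 3 therefore stands well on the weak side of compound 1, while the comparison with its other neighbour gives only a step that the two limits leave unreadable from compound 2 to compound 3 and no order.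

Compound 4 `c1ccc(-c2nn(CCCCCCCCc3nnn[nH]3)c(-c3ccccc3)c2-c2ccccc2)cc1` keeps the shared core and has 1H-tetrazol-5-yl in place of cyano on a saturated chain carbon, eight bonds along the chain from an aromatic nitrogen.

Two measured steps at that same place bear on this change, and both are large: there is an at least 12-fold higher number from compound 1 to compound 2 (1.09 log units; beyond the scatter) and also an at least 13-fold higher number from compound 1 to compound 3 (1.11 log units; beyond the scatter) on the same read-out. Within the data shown here, the end of the chain can thus shift inhibition strongly, but no measured compound carries a ring there, so the size of the next step is uncertain. In this assay the estimated step is an at least 6.0-fold lower number from compound 3 to compound 4 (0.77 log units; beyond the scatter) and it is expected to run towards stronger inhibition. For compound 4 the estimate is 12000 nM (expected range 3000 nM to 60000 nM).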

Compound 4, half-maximal inhibitory concentration: 1040 nM
Estimate against measurement, compound 4: 12-fold (1.06 log units) above; the whole stated range lies above it.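

A ring at the chain end proves to be compatible with inhibition in this assay: the change gives an at least 69-fold lower number from compound 3 to compound 4 (1.84 log units; beyond the scatter) and an at least 65-fold lower number from compound 2 to compound 4 (1.81 log units; beyond the scatter), and even against the best earlier compound there is a 5.3-fold lower number from compound 1 to compound 4 (0.72 log units; beyond the scatter), which makes compound 4 the strongest of the four shown. Compound 3 gives only a limit, so the step that starts from it shows a minimum and not a true size: the limit of > 72000 nM in this assay, at which 1 of the 4 values shown sits. Compound 2 also gives only a limit, and the same caution applies to its step: the limit of > 68000 nM in this assay, at which 1 of the 4 values shown sits.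

The compounds shown leave open whether the gain requires 1H-tetrazol-5-yl itself, or whether another group at this place, such as a sulfonic acid, an amine or a different five-membered aromatic ring, would serve equally well in this assay. They also leave open how much the length of the chain matters, since a shorter or a longer chain carrying 1H-tetrazol-5-yl does not appear among them.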